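The source may report more compounds than this note shows. Statements on the series, on what has been measured and on what is new or still open speak of the compounds shown alone.

Compound 2 `COc1cc(NC(=O)Nc2cc(Nc3cc(I)ccc3OC)ncn2)cc(OC)c1` gives 59% in a functional assay on NCI-H1581 cells (Homo sapiens) for inhibition, read by MTT assay, with a stated time of 48 h, tested at 10 uM (on this read-out lower numbers stand for less inhibition and higher numbers for more inhibition at the one concentration tested (going by the name of the read-out)), the highest of the two numbers in hand. Compound 1 `COc1cc(NC(=O)Nc2cc(Nc3ccc(C)c(C)c3)ncn2)cc(OC)c1` gives 20.1% in this assay. Within the data shown here, the single step between the two, a number 38.9 percentage points higher from compound 1 to compound 2 (beyond the scatter), sits at the same nitrogen on an aromatic ring that is changed again here, and it was large. Compound 3 `COc1cc(NC(=O)Nc2cc(Nc3cc(C)cc(F)c3)ncn2)cc(OC)c1` differs from compound 2 by 3-fluoro-5-methylphenyl in place of 5-iodo-2-methoxyphenyl on a nitrogen on an aromatic ring. Among the measured compounds shown here, the entering 3-fluoro-5-methylphenyl is closer in kind to the 3,4-dimethylphenyl of compound 1, which gave 20.1%, than to the 5-iodo-2-methoxyphenyl of compound 2, so a step back toward the lower number is expected, with one step as the only guide. The expected step is a number 29 percentage points lower from compound 2 to compound 3 (beyond the scatter), downward and beyond the scatter, though probably not the whole way back. Compound 3 is estimated at 30%, within 12% to 50%.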

Compound 3, a percentage reported as inhibition, at one concentration (the size of the read-out at that concentration, not a potency): 28.3%
Compound 3: the middle estimate sits 1.7 percentage points above what was measured; low and high end bracket the measured number.
By their numbers in this assay, from the lowest: compounds 1 and 3 (each within the scatter of the next); then compound 2.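

In this assay, a number 30.7 percentage points lower from compound 2 to compound 3 (beyond the scatter), a second large step at this nitrogen, so a high number does not come with every substituted phenyl placed here. Against that, a number 8.2 percentage points higher from compound 1 to compound 3 (within the scatter): the 3-fluoro-5-methylphenyl and the 3,4-dimethylphenyl are not told apart at this position, and of the three groups only the 5-iodo-2-methoxyphenyl stands clear of the others. No evidence on the origin of these differences is available.

On these data alone, the iodine and the methoxy of the 5-iodo-2-methoxyphenyl leave together in these steps, so their separate contributions stay open. Also open, as far as these compounds go, is how this nitrogen reads with an unsubstituted phenyl, a bromophenyl or a phenyl bearing a carboxylic acid.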